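Swapping the aryl ether arm: from methoxy to fluoro

The source may report more compounds than this note shows. Statements on the series, on what has been measured and on what is new or still open speak of the compounds shown alone.

Of the compounds shown here, three that share one core have been tested in an ADME assay on MT4 cells (Homo sapiens) for cytotoxicity, read by MTT assay, with a stated time of 4 days; a lower number here means that less compound is tolerated, a higher number that more compound is tolerated. Compound 1 `N#Cc1ccc(Nc2nc(Oc3ccccc3Cl)c3ccccc3n2)cc1` gives 38000 nM. Compound 2 `COc1ccccc1Oc1nc(Nc2ccc(C#N)cc2)nc2ccccc12` gives 150000 nM, and compound 3 `CCOc1cc(C#N)cc(OCC)c1Oc1nc(Nc2ccc(C#N)cc2)nc2ccccc12` gives 108000 nM. Compound 2 and compound 3 lie within the usual scatter of each other, while compound 1 is set apart from compound 2 by a 3.9-fold higher number from compound 1 to compound 2 (0.60 log units; beyond the scatter), a change of methoxy in place of chloro on the aromatic carbon of the ether arm.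

Compound 4 `N#Cc1ccc(Nc2nc(Oc3ccc(F)cc3)c3ccccc3n2)cc1` has not been measured. It differs from compound 2 by 4-fluorophenyl in place of 2-methoxyphenyl on an oxygen on an aromatic ring. For the measured compounds named here, the only measured step that touches the same arm is a 3.9-fold higher number from compound 1 to compound 2 (0.60 log units; beyond the scatter), where replacing a halogen with methoxy gave a modestly higher number. Compound 4 takes the methoxy away and brings a halogen back, so a modest step in the opposite direction, toward the number of compound 1, is expected in this assay.

Compound 4 is therefore expected to give about 55000 nM, with a likely range from 20000 nM to 150000 nM. The expected step is a 2.7-fold lower number from compound 2 to compound 4 (0.44 log units; beyond the scatter).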

Compound 4, half-maximal cytotoxic concentration: > 351000 nM
Compound 4 ended at the assay's limit; the forecaster's own chance of this, stated with the estimate: 10%; middle value at least 6.3-fold (0.80 log units) from the limit.
By their numbers in this assay, from the lowest: compound 1; then compounds 3 and 2 (each within the scatter of the next). At a limit, above all of these: compound 4.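

Putting 4-fluorophenyl on this oxygen gives an at least 2.3-fold higher number from compound 2 to compound 4 (0.36 log units; beyond the scatter), and measured against the 2-chlorophenyl arm the same group gives an at least 9.2-fold higher number from compound 1 to compound 4 (0.96 log units; beyond the scatter). A halogen on this ring therefore does not by itself go with a lower number in this assay, since compound 1 and compound 4 both carry one and stand at opposite ends of the series. The entry for compound 4, > 351000 nM, is a limit of the assay and not a number.

The change from 2-chlorophenyl to 4-fluorophenyl swaps the halogen and its place on the ring together, so the compounds shown cannot say which of the two matters. From the compounds shown here alone, it also remains open how this arm would read with an amine or a carboxylic acid on the ring in place of the halogen.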